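The source may report more compounds than this note shows. Statements on the series, on what has been measured and on what is new or still open speak of the compounds shown alone.

Measured compounds:
compound 1, `CCCCCN(CCCCC)C(=O)N1CCN(C(=O)N(c2ccccc2)c2cccc(Cl)c2)[C@H](C(=O)O)C1`: 0.4 nM
compound 2, `CCCCCN(CCCCC)C(=O)N1CCN(C(=O)N(c2ccccc2)c2cccc(Br)c2)[C@H](C(=O)O)C1`: 0.6 nM

Among the measured compounds shown here, in an assay for inhibition of Type-2 angiotensin II receptor (Rattus norvegicus) (a lower number here means a stronger inhibitor, a higher number a weaker inhibitor), compound 2 gives 0.6 nM, the higher of the two numbers, its only neighbour being compound 1 at 0.4 nM, which lies within the scatter. Compound 3, `CCCCCN(CCCCC)C(=O)N1CCN(C(=O)N(c2ccccc2)c2cccc(OC)c2)[C@H](C(=O)O)C1`, differs from compound 2 by methoxy in place of bromo on an aromatic carbon. For the measured compounds named here, the single measured step, a 1.5-fold higher number from compound 1 to compound 2 (0.18 log units; within the scatter), swaps one halogen for another and does not reach a methoxy group, so no direct guide exists. The expected step is therefore modest, a 2.5-fold higher number from compound 2 to compound 3 (0.40 log units; beyond the scatter), and compound 3 is estimated at 1.5 nM, between 0.4 nM and 6 nM.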

Compound 3, half-maximal inhibitory concentration: 7.8 nM
Compound 3: middle estimate off by 5.2-fold (0.72 log units), on the low side; the measured number lies above the stated range.
By their numbers in this assay, from the lowest: compounds 1 and 2 (each within the scatter of the next); then compound 3.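

In this assay the place on the aromatic ring, meta to a large group, turns out to be sensitive to what sits there: methoxy in place of bromo gives a 13-fold higher number from compound 2 to compound 3 (1.11 log units; beyond the scatter) and methoxy in place of chloro gives a 20-fold higher number from compound 1 to compound 3 (1.29 log units; beyond the scatter) in this series. The two halogens had shown no such separation. No evidence at hand bears on why the methoxy compound stands apart.

As far as these compounds go, whether the loss belongs to methoxy alone remains open, since a methyl, a hydroxy or an amine at this place could fall on either side. From the compounds shown here alone, whether fluoro would stay with chloro and bromo is equally open.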